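Chloro on the benzimidazole: a small expected step

This account rests on a few compounds, and the source may have more. Where it says the series, first, only, none or still open, it means among the compounds named here.

Measured compounds:
- compound 1 `CN(CCNCc1cn(CC(=O)O)nn1)CCNc1ccnc2cc(Cl)ccc12`: > 200000 nM
- compound 2 `CN(CCNCc1cn(Cc2nc3ccccc3[nH]2)nn1)CCNc1ccnc2cc(Cl)ccc12`: 120000 nM

Two compounds share one core and differ only in the group on the chain carbon bound to the triazole nitrogen. In a functional assay on NCI-H460 cells (Homo sapiens) for antiproliferative activity, read by sulforhodamine B assay, with a stated time of 72 h (on this read-out higher numbers stand for weaker inhibition and lower numbers for stronger inhibition), compound 1 reaches only (the limit of > 200000 nM in this assay, at which 1 of the 2 values shown sits), which is a limit of the assay and not a number. In this assay, for the measured compounds named here, compound 2 gives 120000 nM, the only actual number among the two values. The step of an at least 1.6-fold lower number from compound 1 to compound 2 (0.22 log units; that floor lies within the scatter) is therefore bounded on one side only, and its floor stays within the scatter, so compound 2 stands as the sole measured reference point here, weakly active.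

Compound 3 `CN(CCNCc1cn(Cc2nc3cc(Cl)ccc3[nH]2)nn1)CCNc1ccnc2cc(Cl)ccc12` differs from compound 2 by chloro in place of hydrogen on an aromatic carbon. No measured step concerns a chloro on this ring, so nothing shown speaks to the size or direction of such a change. Going by the values given here, the only measured step, an at least 1.6-fold lower number from compound 1 to compound 2 (0.22 log units; that floor lies within the scatter), touches a different part of the molecule. With no guidance beyond the scatter, the step of a 1.3-fold lower number from compound 2 to compound 3 (0.12 log units; within the scatter) is expected to stay small. For compound 3 the estimate in this assay is 90000 nM, with a range from 30000 nM to 250000 nM.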

Compound 3, half-maximal inhibitory concentration: 59000 nM
Estimate against measurement, compound 3: 1.5-fold (0.18 log units) above; the measured number falls inside the stated range.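

In this assay, for the compounds shown here, chloro in place of hydrogen on the benzimidazole gives a 2.0-fold lower number from compound 2 to compound 3 (0.31 log units; beyond the scatter), the first step here with a real number at both ends, which shows that this aromatic carbon responds to substitution, though only modestly. Replacing carboxy with 5-chloro-1H-benzimidazol-2-yl gives an at least 3.3-fold lower number from compound 1 to compound 3 (0.53 log units; beyond the scatter), and unlike the floor of the step to compound 2, this floor lies beyond the scatter. That step is bounded on one side only, as compound 1 has a limit of the assay and not a number: the limit of > 200000 nM in this assay, at which 1 of the 3 values shown sits.

The compounds shown leave open whether this modest gain belongs to chloro itself or would also come with fluoro, methyl or methoxy on the same carbon, and whether chloro on another carbon of this ring would do the same. Also open, going by these compounds, is how a longer chain on the aromatic nitrogen would change the number. On these data alone, compound 3 gives 59000 nM, and whether any such change could carry this series to much stronger inhibition also remains open.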